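Cyclopropyl-oxazole in place of bromothiophene on the shared core

A few compounds are considered here, and "the series" means these few. Any claim that something is new, unique, unknown or untested is made for them only; others in the source may bear on it.

Compound 2 `[O-][S+](Cc1cc(Br)cs1)C(c1ccccc1)c1ccccc1` is the most potent of the three compounds measured in an assay on HEK293 cells for inhibition of sodium-dependent dopamine transporter (Homo sapiens), read by scintillation counting, with stated times of 5 min and 1 min (on this read-out higher numbers stand for weaker inhibition and lower numbers for stronger inhibition), where compound 2 gives 13700 nM. Compound 1 `Cc1cc(O)nc(C[S+]([O-])C(c2ccccc2)c2ccccc2)n1` gives 109000 nM in this assay, and compound 3 `COC1NN=C(C[S+]([O-])C(c2ccccc2)c2ccccc2)S1` gives 108000 nM. Both lie clearly apart from compound 2: the step of an 8.0-fold lower number from compound 1 to compound 2 (0.90 log units; beyond the scatter), and the step of a 7.9-fold higher number from compound 2 to compound 3 (0.90 log units; beyond the scatter). Compound 4 `[O-][S+](Cc1cc(C2CC2)on1)C(c1ccccc1)c1ccccc1` keeps the shared core and differs from compound 2 in one place: 5-cyclopropyl-1,2-oxazol-3-yl in place of 4-bromothiophen-2-yl on a saturated chain carbon bound to a sulfur. The two measured steps that bear on this change both pass through compound 2, and both show that exchanging the 4-bromothiophen-2-yl group for a ring richer in hetero atoms, whether the six-membered aromatic ring of compound 1 or the five-membered non-aromatic ring of compound 3, raises the number by a modest but clear amount. The 5-cyclopropyl-1,2-oxazol-3-yl group of compound 4 likewise brings a five-membered aromatic ring with 2 hetero atoms, so a step in the same direction is expected for compound 4, about a 4.4-fold higher number from compound 2 to compound 4 (0.64 log units; beyond the scatter). Compound 4 is therefore estimated at 60000 nM in this assay, within a range from 20000 nM to 150000 nM.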

Compound 4, half-maximal inhibitory concentration: 38600 nM
Beside the measured number, compound 4's estimate is 1.6-fold (0.19 log units) above it; measured number inside the range.
By their numbers in this assay, from the lowest: compound 2; then compound 4; then compounds 3 and 1 (each within the scatter of the next).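

In this assay, 5-cyclopropyl-1,2-oxazol-3-yl in place of 4-bromothiophen-2-yl gives a 2.8-fold higher number from compound 2 to compound 4 (0.45 log units; beyond the scatter) and so leaves compound 2 the most potent of the four. The same group also stands clear of the other two rings, with a 2.8-fold lower number from compound 3 to compound 4 (0.45 log units; beyond the scatter) and a 2.8-fold lower number from compound 1 to compound 4 (0.45 log units; beyond the scatter), so this place on a saturated chain carbon bound to a sulfur now shows an intermediate level rather than only two levels. Nothing among the data shown accounts for this order.

The compounds shown leave open whether the lower number of compound 2 goes with the bromine or with the thiophene ring, which an unsubstituted thiophene or a chlorothiophene at this place would separate. Going by these compounds, how an amine or a carboxylic acid here would read also remains open.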